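The source may report more compounds than this note shows. Statements on the series, on what has been measured and on what is new or still open speak of the compounds shown alone.

Measured compounds:
- compound 1, `CCN1CCN(C(=S)SCCCOc2ccc3c(=O)c(-c4ccc(OC)cc4)coc3c2)CC1`: 36900 nM
- compound 2, `COc1ccc(-c2coc3cc(OCCCCCBr)ccc3c2=O)cc1`: 59100 nM
- compound 3, `COc1ccc(-c2coc3cc(OCCSC(=S)N4CCN(C(=O)OC(C)(C)C)CC4)ccc3c2=O)cc1`: 4090 nM

All three were tested in a functional assay on ECa-109 cells for inhibition, with ECa-109 cell line (Homo sapiens) as the target, read by MTT assay, with a stated time of 48 h; on this read-out lower numbers stand for stronger inhibition and higher numbers for weaker inhibition. Compound 1 gives 36900 nM, which lies close to the number for compound 2 and well above the number for compound 3. The one step among these compounds, a 1.6-fold higher number from compound 1 to compound 2 (0.20 log units; within the scatter), swaps the whole dithiocarbamate-piperazine end for a bromine and stays within the scatter.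

Compound 4, `COc1ccc(-c2coc3cc(OCCCSC(=S)N4CCN(C(C)=O)CC4)ccc3c2=O)cc1`, keeps the chain of compound 1 and differs only at the ring nitrogen: acetyl in place of ethyl on an amine nitrogen in a ring. Among the compounds with values here, no measured step changes this group alone, so nothing directly tells how large the step should be. Compound 3, whose ring nitrogen also carries a carbonyl-bearing group, gives 4090 nM, but its chain is also shorter, so its value cannot be separated into the two changes. Compound 4 is therefore expected to land between compounds 1 and 3, with an estimated step of a 3.1-fold lower number from compound 1 to compound 4 (0.49 log units; beyond the scatter). The estimate for compound 4 is 12000 nM, within a range from 3500 nM to 40000 nM.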

Compound 4, half-maximal inhibitory concentration: 24700 nM
Beside the measured number, compound 4's estimate is 2.1-fold (0.31 log units) below it, and the stated range covers the measured number.
By their numbers in this assay, from the lowest: compound 3; then compounds 4, 1 and 2 (each within the scatter of the next, the first and the last beyond it).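

Read on its own, acetyl in place of ethyl on the amine nitrogen in the ring gives a 1.5-fold lower number from compound 1 to compound 4 (0.17 log units; within the scatter) in this assay. With the chain held fixed, this swap adds a carbonyl and a hydrogen-bond acceptor at this position, yet the two numbers cannot be told apart. An acetyl group at this nitrogen therefore shows no measurable gain or loss over ethyl on this chain, and no measurement at hand offers an explanation for this result.

The compounds shown leave open whether the same swap would also make so little difference on the shorter chain of compound 3. They also leave open how this nitrogen would respond to quite different groups, such as a benzyl group or a plain hydrogen.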